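Formyl to Hydroxymethyl on Two Related Cores

The source may report more compounds than this note shows. Statements on the series, on what has been measured and on what is new or still open speak of the compounds shown alone.

Compound 1 `Cc1cn(/C=C/C=O)c(=O)[nH]c1=O`: 100000 nM
Compound 2 `Cc1cn(/C=C/CO)c(=O)[nH]c1=O`: > 100000 nM, a limit of the assay
Compound 3 `Cc1cn([C@H]2C[C@H](O)[C@@H](CO)O2)c(=O)n(/C=C/C=O)c1=O`: 20000 nM

In a functional assay on HeLa cells (Homo sapiens) for inhibition (on this read-out lower numbers stand for stronger inhibition and higher numbers for weaker inhibition), compound 1 gives 100000 nM. For compound 2 the assay reports only a limit, > 100000 nM. Compound 3 gives 20000 nM, the lowest of the two numbers, with compound 1 next and beyond the scatter. The step of a number no lower from compound 1 to compound 2 (the limit leaves the size open) is the change (hydroxymethyl in place of formyl on a double-bonded chain carbon bound to a double-bonded chain carbon); its size cannot be read because the limit of > 100000 nM in this assay, at which 1 of the 3 values shown sits, is where compound 2 sits. How the core of compound 3 differs from that of compound 1 is not broken down here.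

Compound 4 `Cc1cn([C@H]2C[C@H](O)[C@@H](CO)O2)c(=O)n(/C=C/CO)c1=O` is not yet measured. It differs from compound 3 by hydroxymethyl in place of formyl on a double-bonded chain carbon bound to a double-bonded chain carbon, the same change. The step of a 5.0-fold higher number from compound 3 to compound 4 (0.70 log units; beyond the scatter) is expected, resting on a number no lower from compound 1 to compound 2 (the limit leaves the size open). Compound 4 is therefore expected to give 100000 nM in this assay, most likely between 30000 nM and 300000 nM, possibly only as a limit.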

Compound 4, half-maximal inhibitory concentration: 5000 nM
Compound 4: the middle estimate sits 20-fold (1.30 log units) above what was measured; measured number outside the range, below it.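

In this assay, hydroxymethyl in place of formyl gives a 4.0-fold lower number from compound 3 to compound 4 (0.60 log units; beyond the scatter), so the change does not carry over with one fixed effect from the core of compound 1 to the core of compound 3: the same change on two cores in this assay, a number no lower (the limit leaves the size open) from compound 1 to compound 2 and a 4.0-fold lower number (0.60 log units; beyond the scatter) from compound 3 to compound 4, at least 4.0-fold (0.60 log units) apart, beyond the scatter of two such steps The step from compound 1 to compound 2 cannot be read as a size, since compound 2 stands only at a limit of the assay: the limit of > 100000 nM in this assay, at which 1 of the 4 values shown sits. With one pair on each core, this shows that the outcome of the change depends on the core in this series, but it does not show why, nor does it give a rule for any further core.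

Still open, going by these compounds, is how other groups at this place would behave on the two cores. A carboxylic acid or an amine in place of the formyl, or a longer chain ending in hydroxyl, might show whether the lower number on the core of compound 3 is particular to hydroxymethyl.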